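The source may hold more compounds than are shown below. What is called first, only, known or untested is meant among the compounds shown, and "the series" means these compounds.

Compound 1, `CC(C)=CCC1=C(OCc2cn(C3CCNCC3)nn2)C(=O)c2ccccc2C1=O`, was tested in an ADME assay on HepG2 cells (Homo sapiens) for cytotoxicity, read by MTT assay, with a stated time of 24 h (on this read-out higher numbers stand for lower toxicity in this test and lower numbers for higher toxicity in this test), and gives 570000 nM, the second highest of three numbers. Compound 2, `CC(C)=CCC1=C(OCc2cn(-c3ccc(S(N)(=O)=O)cc3)nn2)C(=O)c2ccccc2C1=O`, gives 483000 nM, and compound 3, `CC(C)=CCC1=C(OCc2cn(-c3ccc(C#N)cc3)nn2)C(=O)c2ccccc2C1=O`, gives 707000 nM. The measured steps are a 1.2-fold lower number from compound 1 to compound 2 (0.07 log units; within the scatter), a 1.2-fold higher number from compound 1 to compound 3 (0.09 log units; within the scatter) and a 1.5-fold higher number from compound 2 to compound 3 (0.17 log units; within the scatter). Compound 4, `CC(C)=CCC1=C(OCc2cn(-c3ccc([N+](=O)[O-])cc3)nn2)C(=O)c2ccccc2C1=O`, differs from compound 1 in one place: 4-nitrophenyl in place of piperidin-4-yl on an aromatic nitrogen. The steps from compound 1 to compound 2 and to compound 3 also swap piperidin-4-yl for a substituted phenyl on the same aromatic nitrogen, and each stayed within the scatter, so no step beyond the scatter is expected in this assay. Compound 4 is therefore estimated at 580000 nM, with a range from 300000 nM to 1100000 nM, an expected step of a 1.0-fold higher number from compound 1 to compound 4 (0.01 log units; within the scatter).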

Compound 4, half-maximal cytotoxic concentration: 540000 nM
Compound 4: middle estimate off by 1.1-fold (0.03 log units), on the high side; the range from low to high includes it.
By their numbers in this assay, from the lowest: compounds 2, 4, 1 and 3 (each within the scatter of the next).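

In this assay, 4-nitrophenyl on this aromatic nitrogen gives a 1.1-fold lower number from compound 1 to compound 4 (0.02 log units; within the scatter), so a third substituted phenyl also stays within the scatter of piperidin-4-yl. Exchanging the group on the phenyl ring does no more, with a 1.3-fold lower number from compound 3 to compound 4 (0.12 log units; within the scatter) and a 1.1-fold higher number from compound 2 to compound 4 (0.05 log units; within the scatter), so nitro, cyano and sulfamoyl cannot be told apart in this test. No measurement is available to explain this flat result. Going by these compounds, it remains open what a carboxylic acid or a dimethylamino group on that phenyl ring would give, and what an unsubstituted phenyl on the same nitrogen would give.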